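The compounds below may be only part of what the source reports. "The series", "measured", "known", "first", "only" and "open" are said of these compounds alone.

Measured so far in an assay on isolated protein for binding affinity to somatostatin receptor type 4 (Homo sapiens), read by radioligand binding; on this read-out higher numbers stand for weaker inhibition and lower numbers for stronger inhibition:
compound 1 `NCCCCCOC[C@H]1O[C@@H](OCCc2c[nH]c3ccccc23)[C@H](OCc2ccccc2)[C@@H](OCc2ccccc2)[C@@H]1OCc1cccnc1`: 360 nM
compound 2 `Cc1ccc(CO[C@H]2[C@H](OCc3ccccc3)[C@@H](OCc3ccccc3)[C@H](OCCc3c[nH]c4ccccc34)O[C@@H]2COCCCCCN)cn1`: 1260 nM

Compound 2 holds the highest of the two numbers in this assay; its nearest neighbour is compound 1, and the step from compound 1 to compound 2 was a 3.5-fold higher number from compound 1 to compound 2 (0.54 log units; beyond the scatter). Compound 3 `NCCCCCOC[C@H]1O[C@@H](OCCc2c[nH]c3ccccc23)[C@H](OCc2ccccc2)[C@@H](OCc2ccccc2)[C@@H]1OCc1c[nH]cn1` differs from compound 2 by 1H-imidazol-4-yl in place of 6-methylpyridin-3-yl on a saturated chain carbon bound to an oxygen on a saturated carbon. Going by the values given here, no measured step exchanges one ring for another; only a 3.5-fold higher number from compound 1 to compound 2 (0.54 log units; beyond the scatter) touches the departing group, through its methyl. The direction is therefore uncertain, and a step of a 2.5-fold lower number from compound 2 to compound 3 (0.40 log units; beyond the scatter) is expected as a rough guess. Compound 3 is estimated at 500 nM, within 120 nM to 2500 nM.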

Compound 3, inhibition constant in the somatostatin receptor type 4 assay: 1040 nM
For compound 3 the middle estimate is 2.1-fold (0.32 log units) below the measured one; the range from low to high includes it.
By their numbers in the somatostatin receptor type 4 assay, from the lowest: compound 1; then compounds 3 and 2 (each within the scatter of the next).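

In the somatostatin receptor type 4 assay, the change to 1H-imidazol-4-yl gives a 1.2-fold lower number from compound 2 to compound 3 (0.08 log units; within the scatter), so this five-membered ring with its hydrogen-bond donor cannot be told apart from 6-methylpyridin-3-yl at this position. Neither ring matches pyridin-3-yl, as the change from that ring shows a 2.9-fold higher number from compound 1 to compound 3 (0.46 log units; beyond the scatter). In a physicochemical assay for acid dissociation, compound 2 gives 6.1 and compound 3 gives 7.2. In the physicochemical assay the same exchange gives a large step, while the binding number stays within the scatter, so for this pair binding does not follow that shift: the measured acid dissociation constant of compound 2, 6.1, and of compound 3, 7.2, a number 1.10 log units higher (beyond the scatter)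

Open remains how a phenyl ring or a carboxylic acid at this position would stand against compound 1.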